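Bulkier anilines on the shared core: from compound 3 to compound 4

A few compounds are considered here, and "the series" means these few. Any claim that something is new, unique, unknown or untested is made for them only; others in the source may bear on it.

Compound 1 `Cc1ccc(Nc2ncc(Cl)c(Nc3ccccc3C)n2)cc1`; compound 2 `Cc1ccccc1Nc1nc(Nc2ccc(N3CCCN(C)CC3)cc2)ncc1Cl`; compound 3 `Cc1ccc(CNc2nc(Nc3ccc(N4CCN(C)CC4)cn3)ncc2Cl)cc1`.

In a functional assay on MCF7 cells (Homo sapiens) for inhibition, read by CCK-8 assay, with a stated time of 48 h (a higher number here means a weaker inhibitor of growth, a lower number a stronger inhibitor of growth), compound 1 gives a value of > 100000 nM, which is a limit of the assay rather than a number. In this assay compound 2 gives 4290 nM. In this assay compound 3 gives 38100 nM, the highest of the two numbers shown, with compound 2 as its nearest neighbour. For the measured compounds named here, the one measured step, an at least 23-fold lower number from compound 1 to compound 2 (1.36 log units; beyond the scatter), rests on the limit described in the limit of > 100000 nM in this assay, at which 1 of the 3 values shown sits.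

Compound 4 `Cc1cc(C)c(Nc2nc(Nc3ccc(N4CCN(C)CC4)cn3)ncc2Cl)c(C)c1` differs from compound 3 by 2,4,6-trimethylphenyl in place of 4-methylbenzyl on a nitrogen on an aromatic ring. Going by the values given here, no measured step touches exactly this change. What the two numbers do show is that compound 2, which carries an arylamino group on the shared core, sits far below compound 3, which carries a benzylamino group. Compound 4 returns to an arylamino group, so a lower number is expected, though the extra methyl groups leave the size uncertain: the step is estimated as a 4.8-fold lower number from compound 3 to compound 4 (0.68 log units; beyond the scatter). Compound 4 is therefore expected to give 8000 nM, in the range 2000 nM to 32000 nM.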

Compound 4, concentration for 50% growth inhibition: 9470 nM
For compound 4 the middle estimate is 1.2-fold (0.07 log units) below the measured one, within the range that was stated.
By their numbers in this assay, from the lowest: compound 2; then compound 4; then compound 3. At a limit, above all of these: compound 1.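

In this assay, for the compounds shown here, replacing (4-methylbenzyl)amino with (2,4,6-trimethylphenyl)amino gives a 4.0-fold lower number from compound 3 to compound 4 (0.60 log units; beyond the scatter), the first measured step at this nitrogen with the rest of the molecule held constant. It shows that the number responds directly to the group on this nitrogen, and that a ring carrying three methyl groups can stand here without raising it. Nothing measured here accounts for the size or direction of this step.

This single step changes both the link to the ring and the methyl groups on it, so their separate contributions remain unresolved. From the compounds shown here alone, it also remains open how an unsubstituted phenyl, a cyclohexyl or a pyridyl group on this nitrogen would compare.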